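Swapping a Saturated Ring for a Fluorinated Aromatic One

The source may hold more compounds than are shown below. What is called first, only, known or untested is meant among the compounds shown, and "the series" means these compounds.

Going by the values given here, compound 2 `COc1ccnc(-c2nc3ccccn3c2NC2CCCC2)c1` gives 27100 nM in an ADME assay on THP-1 cells (Homo sapiens) for cytotoxicity (a higher number here means that more compound is tolerated, a lower number that less compound is tolerated), the highest of the two numbers measured so far. Compound 1 `Cc1ccc2nc(-c3ccccn3)c(Nc3ccc4c(c3)OCCO4)n2c1` gives 16000 nM in this assay, and the gap between the two compounds lies within the usual scatter, so neither can be ranked above the other. Compound 3 `COc1ccnc(-c2nc3ccccn3c2Nc2ccc(F)cc2)c1` has not been measured; it differs from compound 2 by 4-fluorophenyl in place of cyclopentyl on a nitrogen on an aromatic ring. Among the compounds with values here, no measured pair shows this change, so only a shift within the scatter is expected, if anything slightly downward. Compound 3 is estimated at 18000 nM, between 6000 nM and 50000 nM. That estimate means an expected step of a 1.5-fold lower number from compound 2 to compound 3 (0.18 log units; within the scatter).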

Compound 3, half-maximal cytotoxic concentration: 4220 nM
Compound 3: middle estimate off by 4.3-fold (0.63 log units), on the high side; measured number outside the range, below it.
By their numbers in this assay, from the lowest: compound 3; then compounds 1 and 2 (each within the scatter of the next).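

Replacing cyclopentyl with 4-fluorophenyl on this nitrogen gives a 6.4-fold lower number from compound 2 to compound 3 (0.81 log units; beyond the scatter) in this assay, so the group at this one place changes how much compound the cells tolerate. Compounds 1 and 2 differ in more than one place and could not show this. Nothing here explains the drop.

Still open, going by these compounds, is whether the step follows the aromatic ring itself or its fluorine. A plain phenyl on the same nitrogen would separate those two, and a cyclohexyl would test whether ring size plays any part.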